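The source may report more compounds than this note shows. Statements on the series, on what has been measured and on what is new or still open speak of the compounds shown alone.

Compound 1 `CSc1nnc(Cc2ccc(Cl)cc2Oc2ccccc2Cl)[nH]1`, compound 2 `CCSc1nnc(Cc2ccc(Cl)cc2Oc2ccccc2Cl)[nH]1` and compound 3 `CSc1nnc(Cc2ccc(Cl)cc2Oc2ccccc2F)[nH]1` were tested in a functional assay on the whole organism (strain NMRI) with Mus musculus as the target, with a stated time of 60 min, at a dose of 10 mg/kg by the intraperitoneal route; on this read-out lower numbers stand for a weaker effect and higher numbers for a stronger effect at the one dose given. In this assay compound 1 gives 132%, compound 2 gives 140% and compound 3 gives 121%. The change methyl in place of hydrogen on a saturated chain carbon bound to a sulfur made a step of a number 8 percentage points higher from compound 1 to compound 2 (within the scatter). The change fluoro in place of chloro on an aromatic carbon made a step of a number 11 percentage points lower from compound 1 to compound 3 (beyond the scatter). Compound 4 `CCSc1nnc(Cc2ccc(Cl)cc2Oc2ccccc2F)[nH]1` has not yet been measured in this assay. It differs from compound 3 by methyl in place of hydrogen on a saturated chain carbon bound to a sulfur, the same change that turned compound 1 into compound 2, at the same place; the two cores differ by fluoro in place of chloro on an aromatic carbon. For compound 4 a step of about that small size is expected, a number 8 percentage points higher from compound 3 to compound 4 (within the scatter), because the earlier step was a number 8 percentage points higher from compound 1 to compound 2 (within the scatter). Compound 4 is therefore estimated to give 129%, somewhere between 115% and 143%.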

Compound 4, a percentage reported as activity, at one dose (the size of the read-out at that dose, not a potency): 144%
For compound 4 the middle estimate is 15 percentage points below the measured one; measured number outside the range, above it.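

In this assay, the change from methylsulfanyl to ethylsulfanyl gave a number 23 percentage points higher from compound 3 to compound 4 (beyond the scatter), so this step does not carry over from one core to the other at a fixed size: the same change on two cores in this assay, a number 8 percentage points higher (within the scatter) from compound 1 to compound 2 and a number 23 percentage points higher (beyond the scatter) from compound 3 to compound 4, 15 percentage points apart, beyond the scatter of two such steps. The change to fluoro in place of chloro on the ethylsulfanyl compounds gave a number 4 percentage points higher from compound 2 to compound 4 (within the scatter), so its step also differs with the group on the sulfur: the same change on two cores in this assay, a number 11 percentage points lower (beyond the scatter) from compound 1 to compound 3 and a number 4 percentage points higher (within the scatter) from compound 2 to compound 4, 15 percentage points apart, beyond the scatter of two such steps. In these four compounds the two changes therefore do not simply add up, but the data do not show why, nor how either change would behave on another core.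

The compounds shown leave open what a longer chain such as propyl on the sulfur would give. They also leave open the effect of an amine in that place.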